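This account rests on a few compounds, and the source may have more. Where it says the series, first, only, none or still open, it means among the compounds named here.

Measured in a functional assay on A549 cells (Homo sapiens) for cytotoxicity; on this read-out lower numbers stand for an effect already at smaller amounts and higher numbers for an effect only at larger amounts of compound:
Compound 1 `COC1=C(C)C(=O)/C(=C(O)/C=C/c2ccccc2C)C(=O)C1(C)C`: 4.6 ug/mL
Compound 2 `COC1=C(C)C(=O)/C(=C(O)/C=C/c2cc(C)cc(C)c2)C(=O)C1(C)C`: 4.3 ug/mL

Within the data shown here, compound 2, at 4.3 ug/mL, cannot be told apart from the only other measured compound. Among the measured compounds shown here, the single measured step, a 1.1-fold lower number from compound 1 to compound 2 (0.03 log units; within the scatter), put 3,5-dimethylphenyl in place of 2-methylphenyl, so one carbon-only aromatic ring replaced another.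

Compound 3 `COC1=C(C)C(=O)/C(=C(O)/C=C/c2ccco2)C(=O)C1(C)C` changes the same place, on a double-bonded chain carbon bound to a double-bonded chain carbon, but swaps the ring type: furan-2-yl in place of 3,5-dimethylphenyl on a double-bonded chain carbon bound to a double-bonded chain carbon. For the measured compounds named here, no measured compound carries furan-2-yl yet, so the one step offers only weak guidance. Compound 2 sets the starting point with 4.3 ug/mL, and no shift beyond the scatter is expected in this assay, though with a wide margin. The estimated step is a 1.2-fold higher number from compound 2 to compound 3 (0.07 log units; within the scatter). For compound 3 the expected value is 5 ug/mL, with an estimated range from 2.2 ug/mL to 11 ug/mL.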

Compound 3, concentration for half-maximal effect: 10 ug/mL
Compound 3: the middle estimate sits 2.0-fold (0.30 log units) below what was measured, within the range that was stated.
By their numbers in this assay, from the lowest: compounds 2 and 1 (each within the scatter of the next); then compound 3.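

In this assay this position responds to a change of ring type, which the step between the two carbon-only rings did not show: furan-2-yl in place of 3,5-dimethylphenyl gives a 2.3-fold higher number from compound 2 to compound 3 (0.37 log units; beyond the scatter) and furan-2-yl in place of 2-methylphenyl gives a 2.2-fold higher number from compound 1 to compound 3 (0.34 log units; beyond the scatter) and both steps are modest but beyond the usual scatter. Against either methylated phenyl ring, then, furan-2-yl goes with a higher number, meaning that more compound is needed for the effect. Nothing available explains this shift.

The swap changes ring size, brings in a ring oxygen and removes the methyl groups all at once, so the compounds shown cannot separate these changes. As far as these compounds go, how an unsubstituted phenyl ring or a thiophen-2-yl ring would fall at this position remains open.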